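The source may hold more compounds than are shown below. What is called first, only, known or untested is meant among the compounds shown, and "the series" means these compounds.

In an ADME assay on Akata cells (Homo sapiens) for cytotoxicity, with a stated time of 7 days (on this read-out lower numbers stand for higher toxicity in this test and higher numbers for lower toxicity in this test), compound 1 `Nc1nc(OCC(F)(F)F)c2ncn(/C=C3/CC3(CO)CO)c2n1` returns only a limit, > 20000 nM. Compound 2 `CSc1nc(N)nc2c1ncn2/C=C1/CC1(CO)CO` likewise returns a limit, > 20000 nM. The step that the two limits leave unreadable from compound 1 to compound 2 is consequently unreadable, as the limit of > 20000 nM in this assay, at which 2 of the 2 values shown sit, shows. Compound 3 `CCCCCCOc1nc(N)nc2c1ncn2/C=C1/CC1(CO)CO` differs from compound 1 by pentyl in place of trifluoromethyl on a saturated chain carbon bound to an oxygen on an aromatic ring. Going by the values given here, no measured step bears on this change, and the one step recorded gives no readable size. With both measured compounds at the limit, the step expected in this assay is a number no higher from compound 1 to compound 3 (the limit leaves the size open), no change beyond the scatter. Compound 3 is therefore estimated at 20000 nM, with a range from 5000 nM to 40000 nM.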

Compound 3, half-maximal cytotoxic concentration: > 20000 nM
Compound 3 ended at the assay's limit; the forecaster's own chance of this, stated with the estimate: 60%; the middle value sits exactly at the limit.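

Compound 3 also returns only a limit, > 20000 nM. Going by these compounds alone, no step among compound 1, compound 2 and compound 3 can be read in this assay: the limit of > 20000 nM in this assay, at which 3 of the 3 values shown sit. The compounds shown leave open whether changing these groups alters cytotoxicity at all.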